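Chain Length at the Amine: Compound 3 to Compound 4

This account rests on a few compounds, and the source may have more. Where it says the series, first, only, none or still open, it means among the compounds named here.

Measured in an ADME assay on CHO-K1 cells (Cricetulus griseus) for activation, read by fluorescence, tested at 1 uM; on this read-out lower numbers stand for a stronger effect and higher numbers for a weaker effect at the one concentration tested:
compound 1, `COc1cc(/C=C/C2=CC(=O)CC(c3ccc(O)c(OC)c3)N2CCCO)ccc1O`: 91.8%
compound 2, `O=C(/C=C(/C=C/c1ccc(O)cc1)NCCCO)/C=C/c1ccc(O)cc1`: 86.4%
compound 3, `COCCNC(=C\C(=O)/C=C/c1ccc(O)cc1)/C=C/c1ccc(O)cc1`: 82.5%

On these numbers compound 3 stands lowest of the three; compound 2 is nearest to it, within the scatter, and compound 1 is furthest, also within the scatter. Compound 4, `COCCCNC(=C\C(=O)/C=C/c1ccc(O)cc1)/C=C/c1ccc(O)cc1`, differs from compound 3 by methoxymethyl in place of methoxy on a saturated chain carbon, two bonds along the chain from an amine nitrogen. Going by the values given here, one measured step touches the same place: a number 3.9 percentage points lower from compound 2 to compound 3 (within the scatter). That change at the chain carbon stayed within the scatter, and the change from compound 3 to compound 4 is of a similar kind. The step of a number 0.5 percentage points lower from compound 3 to compound 4 (within the scatter) is therefore expected to stay within the scatter. For compound 4 the expected value is 82%, with a range from 72% to 92%.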

Compound 4, a percentage reported as activity, at one concentration (the size of the read-out at that concentration, not a potency): 99.8%
Beside the measured number, compound 4's estimate is 17.8 percentage points below it, outside the stated range (above it).
By their numbers in this assay, from the lowest: compounds 3, 2, 1 and 4 (each within the scatter of the next, the first and the last beyond it).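

In this assay, going by these compounds alone, this chain position turns out to respond to small changes: going from 2-methoxyethyl to 3-methoxypropyl gives a number 17.3 percentage points higher from compound 3 to compound 4 (beyond the scatter) and lies beyond the scatter, which no earlier step here did. Methyl in place of hydrogen on the chain-end oxygen also matters at this chain length, giving a number 13.4 percentage points higher from compound 2 to compound 4 (beyond the scatter) on the weaker side of the read-out. No available measurement explains either step. Still open, going by these compounds, is whether a longer chain, such as 4-methoxybutyl, would carry the trend further, and how an amine or a carboxylic acid at the chain end would read.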